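This account rests on a few compounds, and the source may have more. Where it says the series, first, only, none or still open, it means among the compounds named here.

Measured so far:
compound 1 `CCCCCn1nc2oc(=O)cc(C)c2c1C`, giving 60.6 mg/kg in a functional assay on the whole organism with Mus musculus as the target, in the writhing test; a higher number here means that more compound is needed for the effect, a lower number that less compound is needed;
compound 2 `CCOC(=O)Cc1nn(C)c2oc(=O)cc(C)c12`, whose reading of > 100 mg/kg in this assay is a limit of the assay, not a number.

Compound 1 therefore stands as the only number shown in this assay, the other entry being a limit: the limit of > 100 mg/kg in this assay, at which 1 of the 2 values shown sits. Compound 3 `Cc1cc(=O)oc2nn(C)c(C)c12` differs from compound 1 by hydrogen in place of butyl on a saturated chain carbon bound to an aromatic nitrogen. Among the compounds with values here, no measured step covers this change, so the expectation rests on the shortening of the chain alone: a rise in dose beyond the scatter, with a fair chance that only a limit is reached. The expected step is a 1.8-fold higher number from compound 1 to compound 3 (0.26 log units; within the scatter). Compound 3 is estimated at 110 mg/kg, ranging from 40 mg/kg to 300 mg/kg.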

Compound 3, dose for half-maximal effect: 6.09 mg/kg
The estimate for compound 3 lay 18-fold (1.26 log units) above the measured number, outside the stated range (below it).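

In this assay, the change from butyl to hydrogen on a saturated chain carbon bound to an aromatic nitrogen gives a 10-fold lower number from compound 1 to compound 3 (1.00 log units; beyond the scatter). At this place, then, the pentyl chain of the earlier compound is not needed for the effect, and methyl serves with less compound. Nothing shown accounts for the size of this step.

From the compounds shown here alone, only pentyl and methyl are compared here, so it stays open how a propyl chain, an ethyl chain or a chain ending in an amine would read. The reading of compound 2, > 100 mg/kg, is a limit of the assay and not a number.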